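The source may hold more compounds than are shown below. What is called first, only, known or untested is meant among the compounds shown, and "the series" means these compounds.

Measured compounds:
- compound 2 `O=C(N/N=C\c1cn(Cc2ccc(Cl)cc2)c2cc(F)ccc12)c1c[nH]c2ccccc12`: 18600 nM
- compound 3 `Cn1cc(C(=O)N/N=C\c2cn(Cc3ccc(Cl)cc3)c3cc(F)ccc23)c2ccccc21`: 84200 nM
- compound 1 `COc1ccc(Cn2cc(/C=N\NC(=O)c3c[nH]c4ccc(Br)cc34)c3cc(OC)ccc32)cc1`: 84400 nM

All three were tested in a functional assay on DU-145 cells (Homo sapiens) for cytotoxicity; a lower number here means a stronger inhibitor, a higher number a weaker inhibitor. Compound 2 has the lowest number of the three; compound 3 is a 4.5-fold higher number from compound 2 to compound 3 (0.66 log units; beyond the scatter) away, and compound 1 stands at the same distance, also beyond the scatter.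

The unmeasured compound 4 `COc1ccc(Cn2cc(/C=N\NC(=O)c3c[nH]c4ccccc34)c3ccc(F)cc32)cc1` keeps the shared core of compound 2 and changes a single place: methoxy in place of chloro on an aromatic carbon. Within the data shown here, none of the measured steps concerns this change. Among the measured compounds shown here, the only measured single-site step, from compound 2 to compound 3, alters a hydrogen on an aromatic nitrogen and says nothing about the substituent on the benzyl ring. Compound 1 does carry the 4-methoxybenzyl group, but it differs from compound 2 in further places as well, so its weak result cannot be traced to the methoxy alone; it only shows that a 4-methoxybenzyl compound in this series can be weak.

For the measured compounds named here, with no directly comparable step, the estimate rests on compound 2 itself. A step of a 1.6-fold higher number from compound 2 to compound 4 (0.21 log units; within the scatter) is expected, modest and toward a weaker compound, with wide uncertainty. Compound 4 is therefore estimated at 30000 nM, in a range from 9000 nM to 100000 nM.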

Compound 4, half-maximal inhibitory concentration: 16200 nM
Compound 4: the middle estimate sits 1.9-fold (0.27 log units) above what was measured; low and high end bracket the measured number.
By their numbers in this assay, from the lowest: compounds 4 and 2 (each within the scatter of the next); then compounds 3 and 1 (each within the scatter of the next).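

In this assay, replacing the 4-chlorobenzyl group with 4-methoxybenzyl gives a 1.1-fold lower number from compound 2 to compound 4 (0.06 log units; within the scatter), which lies within the scatter. At this position, on an aromatic carbon para to a large group, chloro and methoxy therefore cannot be told apart in this read-out, even though methoxy has one more heavy atom and a hydrogen-bond acceptor that chloro lacks. No measurement here explains why the two groups read alike.

The compounds shown leave open whether this position accepts groups of a different kind, such as a carboxylic acid, a dimethylamino group or a longer alkoxy chain, or whether the match between chloro and methoxy is limited to these two substituents. They also leave open whether the same swap would stay within the scatter on a core carrying other changes, since this comparison comes from a single matched pair.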